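Replacing ethoxycarbonyl with tert-butyl at the assay limit

A few compounds are considered here, and "the series" means these few. Any claim that something is new, unique, unknown or untested is made for them only; others in the source may bear on it.

Measured in a functional assay on A549 cells (Homo sapiens) for inhibition, read by CCK-8 assay, with a stated time of 48 h; a lower number here means a stronger inhibitor, a higher number a weaker inhibitor:
Compound 1 `COc1cc(-c2ccnc3cc(-c4cccc(C#N)c4)nn23)cc(OC)c1OC`: > 10000 nM
Compound 2 `CCOC(=O)c1ccc(-c2cc3nccc(-c4cc(OC)c(OC)c(OC)c4)n3n2)cc1`: > 10000 nM

Compound 2 stands at > 10000 nM, which is a limit of the assay and not a number. Compound 1 gives the same kind of reading, so neither compound offers a true potency as a starting point.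

Compound 3 `COc1cc(-c2ccnc3cc(-c4ccc(C(C)(C)C)cc4)nn23)cc(OC)c1OC` keeps the shared core of compound 2 and differs in one place. It carries tert-butyl in place of ethoxycarbonyl on an aromatic carbon, para to a large group (tert-butyl in place of ethoxycarbonyl on an aromatic carbon).

Among the compounds with values here, no measured pair yet shows what a single change does in this assay, so any forecast here is uncertain. Compound 3 is expected to stay close to compound 2 because of the limit of > 10000 nM in this assay, at which 2 of the 2 values shown sit, with no step beyond the scatter as the likeliest result and a smaller chance of a real gain in potency. The expected change is a step that the limit leaves unreadable from compound 2 to compound 3. For compound 3 the estimate is 12000 nM, with an expected range of 3000 nM to 30000 nM.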

Compound 3, half-maximal inhibitory concentration: > 10000 nM
Compound 3: only a limit was reported; the forecaster's own chance of this, stated with the estimate: 75%; the middle value lies beyond the limit too.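

Compound 3 gives > 10000 nM, which is a limit of the assay and not a number. No step from compound 1 or compound 2 to compound 3 can be read, because all three compounds share the same reading: the limit of > 10000 nM in this assay, at which 3 of the 3 values shown sit.

The compounds shown leave open how strong each one truly is, and whether exchanging these groups changes potency at all.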